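Ester to sulfonamide on the weakly active biphenyl series

The source may hold more compounds than are shown below. What is called first, only, known or untested is meant among the compounds shown, and "the series" means these compounds.

For the measured compounds named here, compound 1 `CCOC(=O)c1cccc(-c2ccc(OCC)cc2)c1` is the only member of the series with a numerical read-out: in an assay on COS-7 cells for inhibition of patatin-like phospholipase domain-containing protein 2 (Mus musculus) (on this read-out lower numbers stand for stronger inhibition and higher numbers for weaker inhibition), compound 1 gives 50000 nM. Compound 2 `CCOC(=O)c1cccc(-c2ccc(CN3CCCC3)cc2)c1` carries (pyrrolidin-1-yl)methyl in place of ethoxy on an aromatic carbon. For compound 2 the read-out in this assay is a limit, > 200000 nM. The step of an at least 4.0-fold higher number from compound 1 to compound 2 (0.60 log units; beyond the scatter) is therefore known only as a lower bound, resting on (the limit of > 200000 nM in this assay, at which 1 of the 2 values shown sits).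

Compound 3 `CCNS(=O)(=O)c1cccc(-c2ccc(OCC)cc2)c1` differs from compound 1 at the other end of the core: ethylsulfamoyl in place of ethoxycarbonyl on an aromatic carbon. Going by the values given here, no measured step touches this group, so the single measured step gives no direct guidance; it shows only that the series sits close to the limit of this assay. Compound 3 is expected to give 60000 nM, with a range from 20000 nM to 200000 nM. The expected step of a 1.2-fold higher number from compound 1 to compound 3 (0.08 log units; within the scatter) stays within the scatter.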

Compound 3, half-maximal inhibitory concentration: 200000 nM
Estimate against measurement, compound 3: 3.3-fold (0.52 log units) below; the measured number falls inside the stated range.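

Both ends of the core now have a read: the step at the ethoxycarbonyl end is a measured one, and in this assay ethylsulfamoyl in place of ethoxycarbonyl gives a 4.0-fold higher number from compound 1 to compound 3 (0.60 log units; beyond the scatter). This position therefore does not tolerate every change, and this exchange, which also enters one hydrogen-bond donor, weakens inhibition rather than improving on compound 1. The gain in range is small, and the number for compound 3 needs cautious reading beside the one ceiling seen in the series: the limit of > 200000 nM in this assay, at which 1 of the 3 values shown sits.

As far as these compounds go, whether the loss follows from the sulfamoyl group itself or from the ethyl chain on its nitrogen stays open. Equally open, from the compounds shown here alone, is how a carboxylic acid, a primary amide or an unsubstituted sulfamoyl group would read at this position on the core of compound 1.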